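Swapping the group on the aromatic nitrogen

The source may hold more compounds than are shown below. What is called first, only, known or untested is meant among the compounds shown, and "the series" means these compounds.

Measured in a functional assay on NCI-H727 cells (Homo sapiens) for cytotoxicity, read by cell counting, with a stated time of 48 h; a lower number here means a stronger inhibitor, a higher number a weaker inhibitor:
- compound 1 `Cc1ccc(-n2cc(COc3cccc4cnc(Nc5cccc(Cl)c5)nc34)nn2)c([N+](=O)[O-])c1`: > 25000 nM (a limit)
- compound 2 `Clc1ccc(-n2cc(COc3cccc4cnc(Nc5cccc(Cl)c5)nc34)nn2)cc1`: > 25000 nM (a limit)
- compound 3 `COc1cccc(-n2cc(COc3cccc4cnc(Nc5cccc(Cl)c5)nc34)nn2)c1`: > 25000 nM (a limit)

In this assay compound 3 gives > 25000 nM, which is a limit and not a number. It therefore has no rank against the other two compounds, and the series as measured is summed up by the limit of > 25000 nM in this assay, at which 3 of the 3 values shown sit.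

Compound 4 `Clc1cccc(Nc2ncc3cccc(OCc4cn(-c5cc(Cl)cc(Cl)c5)nn4)c3n2)c1` carries 3,5-dichlorophenyl in place of 3-methoxyphenyl on an aromatic nitrogen.

Three measured changes at the same nitrogen bear on this one: a step that the two limits leave unreadable from compound 1 to compound 2, a step that the two limits leave unreadable from compound 1 to compound 3 and a step that the two limits leave unreadable from compound 2 to compound 3. None of them has a readable size, so they give no direction for the new group. The closest guide is compound 2, which also has a chlorine-bearing phenyl group and gives > 25000 nM, again a limit.

No step beyond the scatter is expected in this assay, and compound 4 will most likely be reported only as a limit. The expected outcome is a step that the limit leaves unreadable from compound 3 to compound 4. For compound 4 the estimated value is 30000 nM, with an expected range from 15000 nM to 60000 nM.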

Compound 4, half-maximal inhibitory concentration: 7000 nM
Compound 4: the middle estimate sits 4.3-fold (0.63 log units) above what was measured, and the stated range ends above it.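

In this assay, the group on the aromatic nitrogen of the five-membered ring can move the read-out off the limit, as 3,5-dichlorophenyl gives an at least 3.5-fold lower number from compound 3 to compound 4 (0.55 log units; beyond the scatter), along with an at least 3.5-fold lower number from compound 2 to compound 4 (0.55 log units; beyond the scatter) and an at least 3.5-fold lower number from compound 1 to compound 4 (0.55 log units; beyond the scatter). Compound 2 gives > 25000 nM, which is a limit, so the single chlorine of 4-chlorophenyl does not produce a measurable value in this series. Compound 4 is the only one of the four with a number rather than a limit, and the other three share one limit: the limit of > 25000 nM in this assay, at which 3 of the 4 values shown sit.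

Going by these compounds, the steps among compound 1, compound 2 and compound 3 cannot be read, and the steps to compound 4 give only a minimum size, so the full effect of the change stays open. Also open, on these data alone, is whether the gain follows the two chlorine atoms or their placing in 3,5-dichlorophenyl, a question that 3-chlorophenyl, 3,5-dimethylphenyl or 3,5-difluorophenyl on the same nitrogen would address.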